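The compounds below may be only part of what the source reports. "The series", "measured", "known", "first", "only" and "open" are said of these compounds alone.

Compound 1 `COc1cncc(C2=CC3CC(C2)CN(C)C3)c1` serves as the starting point. In an in vitro assay on SH-SY5Y cells for displacement of a labelled ligand from Neuronal acetylcholine receptor; alpha3/beta4 (Homo sapiens) (on this read-out lower numbers stand for stronger inhibition and higher numbers for weaker inhibition), compound 1 gives 596 nM. Compound 2 `COc1cc(C2=CC3CC(C2)CN(C)C3)cnc1Cl` carries one alteration, (chloro in place of hydrogen on an aromatic carbon), placed on an aromatic carbon of a six-membered aromatic ring with 1 nitrogen, next to the ring nitrogen, ortho to a methoxy group and para to a large group; in this assay compound 2 gives 1430 nM, and the step of a 2.4-fold higher number from compound 1 to compound 2 (0.38 log units; beyond the scatter) is a modest loss.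

Compound 3 `C1=C(c2cncc(Oc3ccccc3)c2)CC2CNCC1C2` has a different core, and how its core differs from that of compound 1 is not broken down here. In this assay compound 3 gives 1.9 nM, the lowest of the three values.

Compound 4 `Clc1ccccc1Oc1cncc(C2=CC3CNCC(C2)C3)c1` has not yet been measured. It differs from compound 3 by chloro in place of hydrogen on an aromatic carbon, here on an aromatic carbon of a six-membered aromatic ring of carbon only, ortho to a large group, so this is the same kind of change as before, but at a different place. Because compound 1 to compound 2 gave a 2.4-fold higher number from compound 1 to compound 2 (0.38 log units; beyond the scatter), a small weakening is expected for compound 4, a 1.6-fold higher number from compound 3 to compound 4 (0.20 log units; within the scatter). For compound 4 the value in this assay is estimated at 3 nM, between 1 nM and 10 nM.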

Compound 4, inhibition constant: 26 nM
Beside the measured number, compound 4's estimate is 8.7-fold (0.94 log units) below it, outside the stated range (above it).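

Replacing hydrogen with chloro on the phenyl group gives a 14-fold higher number from compound 3 to compound 4 (1.14 log units; beyond the scatter) in this assay, a large loss of binding strength. Set beside the earlier step, this shows that the change does not carry over with a fixed size from one core to another: the same change on two cores in this assay, a 2.4-fold higher number (0.38 log units; beyond the scatter) from compound 1 to compound 2 and a 14-fold higher number (1.14 log units; beyond the scatter) from compound 3 to compound 4, 5.7-fold (0.76 log units) apart, beyond the scatter of two such steps The number rises in both pairs, but the chloro also sits in a different kind of ring in each, so these two steps cannot show whether the core, the place of the chloro or both account for the gap.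

The compounds shown leave open how other groups, such as fluoro, a nitrile or an amine, would compare with chloro at this same place on the phenyl ring. They also leave open whether the change from phenyl to 2-chlorophenyl would cost as much on a different core, which would separate the role of the core from that of the place.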